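This account rests on a few compounds, and the source may have more. Where it says the series, first, only, none or still open, it means among the compounds named here.

Compound 2, whose structure is `COc1ccc(S(=O)(=O)N(CC(N)=O)c2ccc(N(CC(N)=O)S(=O)(=O)c3ccc(NC(=O)CN4CCN(C(C)C)CC4)cc3)c3ccccc23)cc1`, stands at the edge of what this study can report. In a functional assay on cells (Peritoneal macrophage, Mus musculus) for cytotoxicity, with a stated time of 24 h (a lower number here means that less compound is tolerated, a higher number that more compound is tolerated), compound 2 gives > 100000 nM, and that figure is a limit of the assay, not a measured number. Its nearest neighbour, compound 1 `COc1ccc(S(=O)(=O)N(CC(N)=O)c2ccc(N(CC(N)=O)S(=O)(=O)c3ccc(NC(=O)CN4CCC(C)CC4)cc3)c3ccccc23)cc1`, is in the same position: in this assay compound 1 gives > 50000 nM, again a limit rather than a value. Within the data shown here, the only measured step, a step that the two limits leave unreadable from compound 1 to compound 2, therefore cannot be read, because both of its ends sit at limits, one at the limit of > 100000 nM in this assay, at which 1 of the 2 values shown sits, and the other at the limit of > 50000 nM in this assay, at which 1 of the 2 values shown sits. Compound 3, with structure `COc1ccc(S(=O)(=O)N(CC(N)=O)c2ccc(N(CC(N)=O)S(=O)(=O)c3ccc(NC(=O)CCN4CCCCC4)cc3)c3ccccc23)cc1`, differs from compound 2 by (piperidin-1-yl)methyl in place of 4-isopropylpiperazin-1-yl on a saturated chain carbon bound to a carbonyl carbon. No readable step bears on this change, so the numbers give no direction and no size for it; the only expectation they allow is that compound 3 falls where compound 1 and compound 2 already lie, with any step beyond the scatter unsupported. Compound 3 is thus expected to give about 100000 nM in this assay, within a range from 30000 nM to 300000 nM, and the expected step of a number no higher from compound 2 to compound 3 (the limit leaves the size open) is one of no change beyond the scatter.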

Compound 3, half-maximal cytotoxic concentration: > 100000 nM
Compound 3 gave a limit, no number; the forecaster's own chance of this, stated with the estimate: 75%; the middle value sits exactly at the limit.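

In this assay compound 3 gives > 100000 nM, which is a limit of the assay and not a number. The steps joining compound 3 to compound 1 and to compound 2 cannot be read, since each has limits at both ends: the limit of > 100000 nM in this assay, at which 2 of the 3 values shown sit. The compounds shown leave open where the half-maximal cytotoxic concentration of each lies, and whether exchanging these groups changes it at all.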